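Compound 2 and its propyl to ethyl step

This account rests on a few compounds, and the source may have more. Where it says the series, first, only, none or still open, it means among the compounds named here.

Compound 1 (`CC(C)CN(Cc1ccc(N2CCN(NS(C)(=O)=O)CC2)cc1)S(=O)(=O)Cc1ccccc1`): (<= 1000 nM), a limit
Compound 2 (`CCCN(Cc1ccc(N2CCN(C(C)=O)CC2)cc1)S(=O)(=O)Cc1ccccc1`): (40000 nM)

Both compounds were tested in a physicochemical assay for solubility, in phosphate buffer, measured as kinetic solubility, with a stated time of 24 h, at pH 7.4 (on this read-out higher numbers stand for higher solubility and lower numbers for lower solubility), as the read-out. For compound 1 the entry (<= 1000 nM) is a limit of the assay and not a number. Among the measured compounds shown here, compound 2 (40000 nM) holds the only actual number so far, so it has no second number to stand against.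

Compound 3 (`CCN(Cc1ccc(N2CCN(C(C)=O)CC2)cc1)S(=O)(=O)Cc1ccccc1`) has not yet been measured. It carries hydrogen in place of methyl on a saturated chain carbon, two bonds along the chain from a sulfonamide nitrogen, which reads as propyl to ethyl. For the measured compounds named here, no measured step shows what this change does, so the expectation starts from compound 2 (40000 nM) and the modest size of the change. The estimated step (a 1.3-fold higher number from compound 2 to compound 3 (0.10 log units; within the scatter)) is expected to lean slightly upward and stay within the usual scatter. Compound 3 is expected to read (50000 nM) with an estimated range from 20000 nM to (120000 nM).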

Compound 3, solubility: 31000 nM
Estimate against measurement, compound 3: 1.6-fold (0.21 log units) above; the measured number falls inside the stated range.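

Replacing propyl with ethyl, with hydrogen in place of methyl on a saturated chain carbon, two bonds along the chain from a sulfonamide nitrogen, gives a 1.3-fold lower number from compound 2 to compound 3 (0.11 log units; within the scatter) in this assay and so stays within the usual scatter. This pair gives the position its first readable step, and on this read-out the chain can be cut by this one carbon with no difference beyond the scatter. Nothing shown here bears on why the two values lie so close.

Still open, from the compounds shown here alone, is whether a longer chain such as butyl, or a chain ending in an amine or a carboxylic acid, would stay within the scatter at this place. Also open, going by these compounds, is whether the same step would read alike on the core of compound 1, whose entry is a limit.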